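A few compounds are considered here, and "the series" means these few. Any claim that something is new, unique, unknown or untested is made for them only; others in the source may bear on it.

The measured compounds:

Compound 1, `O=C1NCCc2nc(C#Cc3ccccc3)sc21`, in an assay on HEK293 cells for negative allosteric modulation of metabotropic glutamate receptor 5 (Homo sapiens), read by FLIPR, with a stated time of 1 h (a lower number here means a stronger inhibitor, a higher number a weaker inhibitor), gives > 10000 nM, which is a limit of the assay and not a number.
Compound 2, `O=C1NCCc2nc(C#Cc3ccccc3F)sc21`, gives > 10000 nM, likewise a limit.
Compound 3, `CC1CC1C(=O)N1CCc2nc(C#Cc3ccccc3)sc2C1`, gives > 10000 nM, again a limit.

Compound 3 thus stands at the weak end of what this assay can report: its value is only a limit, and the two other compounds share the same position, as summed up by the limit of > 10000 nM in this assay, at which 3 of the 3 values shown sit. No real number exists here against which a change could be measured.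

The change from compound 3 to compound 4, `N#Cc1cccc(C(=O)N2CCc3nc(C#Cc4ccccc4)sc3C2)c1`, is 3-cyanophenyl in place of 2-methylcyclopropyl on a carbonyl carbon. For the measured compounds named here, only one measured step exists, a step that the two limits leave unreadable from compound 1 to compound 2, and it concerns a different part of the molecule; its size cannot be read because the limit of > 10000 nM in this assay, at which 3 of the 3 values shown sit, covers both of its ends. It therefore gives no guide to the present change, and no step beyond the scatter can be foreseen in either direction. Nothing measured shows any compound of this series reaching a readable half-maximal inhibitory concentration.

Compound 4 is therefore expected to give an estimated 8000 nM, with a range from 1500 nM to 30000 nM, and most likely only a limit again. The expected at least 1.2-fold lower number from compound 3 to compound 4 (0.09 log units; that floor lies within the scatter) is itself read from a limit and carries that uncertainty.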

Compound 4, half-maximal inhibitory concentration: > 10000 nM
Compound 4: a limit, no number; the forecaster's own chance of this, stated with the estimate: 60%; at least 1.2-fold (0.09 log units) between middle value and limit.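

For the compounds shown here, compound 3 and compound 4 both end at a limit and not a number, so putting 3-cyanophenyl in place of 2-methylcyclopropyl on the carbonyl carbon gives no step whose size can be read: the limit of > 10000 nM in this assay, at which 4 of the 4 values shown sit.

The compounds shown leave open what kind of structure, if any, would give a readable half-maximal inhibitory concentration in this assay.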